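The source may report more compounds than this note shows. Statements on the series, on what has been measured and on what is new or still open speak of the compounds shown alone.

Measured so far:
compound 1 `CCN(CC)C(=O)N1CCN(c2ccccc2)CC1` — 15.5%
compound 2 `CCN(CC)C(=O)Nc1cccc(C(=O)O)c1` — 6.87%

In an ADME assay on the whole organism with Mus musculus as the target, in the forced swim test, with stated times of 1 h and 5 min, at a dose of 10 mg/kg (a higher number here means more inhibition at the dose given (going by the name of the read-out), a lower number less inhibition), compound 1 gives 15.5% and compound 2 gives 6.87%. Compound 2 holds the lower of the two numbers shown, with compound 1 the nearest, but the gap between them lies within the scatter, so nothing is read into it. Compound 3 `CCN(CC)C(=O)Nc1ccccc1` is not yet measured. It differs from compound 2 by hydrogen in place of carboxy on an aromatic carbon. Within the data shown here, no step between measured compounds is known for this change. In this assay a small rise is expected, a number 5.1 percentage points higher from compound 2 to compound 3 (within the scatter), not clearly beyond the scatter. Compound 3 is expected to give 12%, in the range 0% to 28%.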

Compound 3, a percentage reported as inhibition, in the whole organism at one dose (the size of the read-out at that dose, not a potency): 6.6%
Estimate against measurement, compound 3: 5.4 percentage points above, within the range that was stated.
By their numbers in this assay, from the lowest: compounds 3, 2 and 1 (each within the scatter of the next).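

In this assay, among these compounds, hydrogen in place of carboxy on the aromatic carbon gives a number 0.3 percentage points lower from compound 2 to compound 3 (within the scatter), the first direct reading for this position. At this dose, the read-out therefore does not separate compound 3 from its carboxy-bearing counterpart, compound 2, so losing these 3 heavy atoms, with their hydrogen-bond donor and acceptor, brings no change beyond the scatter. Nothing available explains this result. Still open, as far as these compounds go, is whether an amine or a longer alkyl chain on this aromatic carbon would move the read-out beyond the scatter.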